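The source may hold more compounds than are shown below. What is called first, only, known or untested is meant among the compounds shown, and "the series" means these compounds.

Compound 1 `COc1cc(-n2cnc3ccc(-c4cccc(N)c4)cc32)cc(OC)c1OC` gives in a functional assay on SGC-7901 cells (Homo sapiens) for antiproliferative activity, read by MTT assay, with a stated time of 72 h (a lower number here means a stronger inhibitor, a higher number a weaker inhibitor), 21 nM.
Compound 2 `COc1cc(-n2cnc3ccc(-c4cc(F)ccc4F)cc32)cc(OC)c1OC` gives in this assay 6590 nM.
Compound 3 `COc1cc(-n2cnc3ccc(-c4ccc(Cl)cc4Cl)cc32)cc(OC)c1OC` reaches in this assay only a limit of the assay, > 10000 nM.

The three compounds share one core and differ only in the aryl group attached to it. Compound 3 stands at the floor of what this assay reports, with no number of its own, (the limit of > 10000 nM in this assay, at which 1 of the 3 values shown sits). Compound 2 sits close to it: an at least 1.5-fold higher number from compound 2 to compound 3 (0.18 log units; that floor lies within the scatter). The move from compound 1 was large in both cases, a 310-fold higher number from compound 1 to compound 2 (2.50 log units; beyond the scatter) and an at least 470-fold higher number from compound 1 to compound 3 (2.67 log units; beyond the scatter).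

Compound 4 `COc1cc(-n2cnc3ccc(-c4ccc(O)cc4)cc32)cc(OC)c1OC`, not yet measured, changes compound 3 in one place: 4-hydroxyphenyl in place of 2,4-dichlorophenyl on an aromatic carbon. Going by the values given here, the step that bears on it most is the one from compound 1 to compound 3, an at least 470-fold higher number from compound 1 to compound 3 (2.67 log units; beyond the scatter), where a 3-aminophenyl carrying one hydrogen-bond donor gave way to a 2,4-dichlorophenyl carrying none; 4-hydroxyphenyl brings back one donor and one acceptor, so a large step in the opposite direction, toward compound 1, is expected. Whether all of that ground is recovered cannot be judged from three compounds. The estimate for compound 4 is 60 nM, between 10 nM and 600 nM. That estimate means an expected step of an at least 160-fold lower number from compound 3 to compound 4 (2.22 log units; beyond the scatter).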

Compound 4, half-maximal inhibitory concentration: > 10000 nM
Compound 4: a limit, no number (the forecaster's own chance of this, stated with the estimate: 5%); middle value at least 160-fold (2.22 log units) from the limit.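

At this position a hydrogen-bond donor on the aryl group is not enough to keep the activity of compound 1, as 4-hydroxyphenyl in place of 3-aminophenyl gives an at least 470-fold higher number from compound 1 to compound 4 (2.67 log units; beyond the scatter). With 4-hydroxyphenyl in place of 2,5-difluorophenyl the result is an at least 1.5-fold higher number from compound 2 to compound 4 (0.18 log units; that floor lies within the scatter), so in this assay compound 4 cannot be set apart from compound 2, and the step between compound 3 and compound 4 cannot be read. Among the four aryl groups only the 3-aminophenyl of compound 1 stands clear of the others, and compound 4 joins compound 3 at a limit, not a number: the limit of > 10000 nM in this assay, at which 2 of the 4 values shown sit.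

The compounds shown leave open whether the amine itself or its place on the ring goes with the activity of compound 1, since 4-aminophenyl and 3-hydroxyphenyl are not among them. They also leave open whether a group such as aminomethyl or a carboxylic acid on the same ring would stay near compound 1 or end at the same limit.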